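Replacing the tetrazole arm of a long-lived compound

This account rests on a few compounds, and the source may have more. Where it says the series, first, only, none or still open, it means among the compounds named here.

In an ADME assay on microsomes from liver (Homo sapiens) for metabolic stability (on this read-out lower numbers stand for a shorter-lived compound and higher numbers for a longer-lived compound), compound 1 (`CC(C)C(Cc1nnc[nH]1)c1ccc(-c2ccc3cccc(F)c3c2)[nH]c1=O`) gives 0.307 h and compound 2 (`CC(C)C(c1nnc[nH]1)c1ccc(-c2ccc3cccc(F)c3c2)[nH]c1=O`) gives 0.905 h. Compound 3 (`CC(C)C(Cc1nnn[nH]1)c1ccc(-c2ccc3cccc(F)c3c2)[nH]c1=O`) gives > 3 h, which is a limit of the assay and not a number. It therefore stands at the limit of > 3 h in this assay, at which 1 of the 3 values shown sits.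

Compound 4 (`CC(C)C(c1ccc(-c2ccc3cccc(F)c3c2)[nH]c1=O)N1CCNC1=O`) is not yet measured. It differs from compound 3 as follows: 2-oxoimidazolidin-1-yl in place of (1H-tetrazol-5-yl)methyl on a saturated chain carbon bound to an aromatic carbon and a saturated chain carbon.

Going by the values given here, three measured steps bear on this change, and all lie beyond the scatter. Removing the methyl link from the triazole arm gave a 2.9-fold higher number from compound 1 to compound 2 (0.47 log units; beyond the scatter). Placing 1H-tetrazol-5-yl in the triazole's position on the chain gave an at least 9.7-fold higher number from compound 1 to compound 3 (0.98 log units; beyond the scatter). Changing the group at the very place now being altered gave an at least 3.3-fold higher number from compound 2 to compound 3 (0.52 log units; beyond the scatter).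

Among the compounds with values here, no measured compound carries the 2-oxoimidazolidin-1-yl group, so any forecast is uncertain. The nearest guide is compound 2, which also has no methyl link and gives 0.905 h. Leaving the tetrazole arm behind is thus expected to shorten the half-life, and the estimated change in this assay is an at least 3.0-fold lower number from compound 3 to compound 4 (0.47 log units; beyond the scatter).

For compound 4 the expected half-life is 1 h, with an estimated range from 0.3 h to 3.5 h.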

Compound 4, half-life: 1.03 h
Compound 4: middle estimate off by 1.0-fold (0.01 log units), on the low side; the range from low to high includes it.
By their numbers in this assay, from the lowest: compound 1; then compounds 2 and 4 (each within the scatter of the next). At a limit, above all of these: compound 3.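

In this assay, the non-aromatic 2-oxoimidazolidin-1-yl ring cannot be told apart from the aromatic 4H-1,2,4-triazol-3-yl ring at this place, with a 1.1-fold higher number from compound 2 to compound 4 (0.06 log units; within the scatter), and it stands clear of the (4H-1,2,4-triazol-3-yl)methyl arm, with a 3.4-fold higher number from compound 1 to compound 4 (0.53 log units; beyond the scatter). Among these compounds, then, an aromatic ring at this carbon is not needed for a half-life of this size, yet the (1H-tetrazol-5-yl)methyl arm stays ahead, with an at least 2.9-fold lower number from compound 3 to compound 4 (0.46 log units; beyond the scatter). Compound 3 carries a limit of the assay and not a number, so the full size of that gap stays unknown: the limit of > 3 h in this assay, at which 1 of the 4 values shown sits.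

Still open, going by these compounds, is whether the long half-life of compound 3 belongs to the tetrazole ring or to its methyl link, and a 1H-tetrazol-5-yl group at this place with no link, or a (2-oxoimidazolidin-1-yl)methyl group, would separate the two. Also open, on these data alone, is whether the carbonyl of the new ring matters, which a pyrrolidin-1-yl ring on the same carbon could test.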